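The source may report more compounds than this note shows. Statements on the series, on what has been measured and on what is new or still open speak of the compounds shown alone.

Measured compounds in a physicochemical assay for solubility, measured as kinetic solubility, at pH 2; a higher number here means a more soluble compound, a lower number a less soluble compound:

- compound 1 `CC(C)[C@H](C[C@H]1OC(=O)NC1=O)c1ccc(-c2ccc3cccc(F)c3c2)[nH]c1=O` gives 24400 nM
- compound 2 `C/C(=C1/OC(=O)NC1=O)C(c1ccc(-c2ccc3cccc(F)c3c2)[nH]c1=O)C(C)C` gives 12700 nM
- compound 3 `CC(C)(/C=C1\OC(=O)NC1=O)c1ccc(-c2ccc3cccc(F)c3c2)[nH]c1=O` gives 1660 nM

Among these three, compound 1 has the highest number. Its nearest neighbour is compound 2, and the gap between them lies within the usual scatter of this kind of measurement, so the two cannot be told apart on this evidence. Compound 3 sits well below both, and that gap does lie beyond the scatter.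

The step considered here leads from compound 1 to compound 4 `CC(C)[C@@H](c1ccc(-c2ccc3cccc(F)c3c2)[nH]c1=O)[C@H]1OC(=O)NC1=O`, which has not yet been measured in this assay. The change is a small one on the chain that carries the ring with two carbonyls:

2,4-dioxo-1,3-oxazolidin-5-yl in place of (2,4-dioxo-1,3-oxazolidin-5-yl)methyl on a saturated chain carbon bound to an aromatic carbon and a saturated chain carbon

One chain carbon is thus taken out, and the 2,4-dioxo-1,3-oxazolidin-5-yl group now sits directly on the saturated chain carbon bound to an aromatic carbon and a saturated chain carbon. Within the data shown here, no measured pair shows exactly this kind of change, so any expectation rests only on the spread of the three values. Because compound 1 gives 24400 nM and the saturated chain is kept, the step from compound 1 to compound 4 is expected to be small, a 1.6-fold lower number from compound 1 to compound 4 (0.21 log units; within the scatter), with a slight downward lean that may not exceed the scatter. Compound 4 is therefore estimated at 15000 nM, within a range from 5000 nM to 40000 nM.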

Compound 4, solubility: 5400 nM
Estimate against measurement, compound 4: 2.8-fold (0.44 log units) above, and the stated range covers the measured number.
By their numbers in this assay, from the lowest: compound 3; then compound 4; then compounds 2 and 1 (each within the scatter of the next).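

In this assay, removing one chain carbon gives a 4.5-fold lower number from compound 1 to compound 4 (0.65 log units; beyond the scatter), with the 2,4-dioxo-1,3-oxazolidin-5-yl group now sitting directly on the saturated chain carbon bound to an aromatic carbon and a saturated chain carbon. Among these compounds, this is the first readable step at this position, and it shows that the read-out responds to the length of the link: the ring itself stays the same, as do the hydrogen-bond donor and acceptor counts of the group, yet the step lies beyond the usual scatter of repeated measurements. No measured evidence on the cause of this step is available here.

Among the compounds shown here, with only one step at this position, it remains open whether the read-out would keep moving in a steady way with link length, which a longer chain carrying the same ring could test. As far as these compounds go, it also remains open whether the link matters in the same way for other groups in this place, such as a carboxylic acid or an amine.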